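Thiophene-linked acids for free fatty acid receptor 1

The source may report more compounds than this note shows. Statements on the series, on what has been measured and on what is new or still open speak of the compounds shown alone.

Measured so far:
compound 1 `Cc1cccc(C)c1-c1cccc(OCc2cn(CCC(=O)O)nn2)c1`: 14700 nM
compound 2 `CC#CC(CC(=O)O)c1ccc(OCc2cccc(-c3c(C)cccc3C)c2)s1`: 210 nM

Notes on the series. In a functional assay on cells for agonist activity at Free fatty acid receptor 1 (Homo sapiens), read by calcium flux (on this read-out higher numbers stand for an effect only at larger amounts of compound and lower numbers for an effect already at smaller amounts), compound 1 gives 14700 nM, whereas compound 2 gives 210 nM. Compound 2 thus holds the lowest number of the two; the gap to compound 1 lies well beyond the scatter of repeated measurements, so compound 2 is clearly the more potent of the pair on this read-out. The two compounds differ in more than one place, so no single change accounts for that gap.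

Compound 3 `CCO[C@H](CC(=O)O)c1ccc(OCc2cccc(-c3c(C)cccc3C)c2)s1` remains to be measured. It keeps the full shared core of compound 2 and changes only the side chain that carries the acid: 2-carboxy-1-ethoxyethyl in place of 1-(carboxymethyl)but-2-yn-1-yl on an aromatic carbon. The acid itself and its distance from the ring are retained; only the branch on the carbon bearing the acid chain changes.

Among the measured compounds shown here, no measured pair in this set isolates that change, so the size of the step rests on judgement. The expected step from compound 2 to compound 3 is a 1.7-fold higher number from compound 2 to compound 3 (0.22 log units; within the scatter), small and close to the scatter, leaning towards a somewhat higher number. Compound 3 is estimated at 350 nM, with a range of 100 nM to 1200 nM.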

Compound 3, half-maximal effective concentration: 50 nM
For compound 3 the middle estimate is 7.0-fold (0.85 log units) above the measured one, and the stated range ends above it.
By their numbers in this assay, from the lowest: compound 3; then compound 2; then compound 1.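

In this assay the position on the five-membered aromatic ring next to the ring sulfur tolerates a change of branch and also responds to it: 2-carboxy-1-ethoxyethyl in place of 1-(carboxymethyl)but-2-yn-1-yl gives a 4.2-fold lower number from compound 2 to compound 3 (0.62 log units; beyond the scatter) and counts as a modest step. The triple bond is therefore not needed for activity at this level, since compound 3 has lost it and carries an ethoxy branch and a defined stereocentre instead, with the acid chain and the rest of the shared core unchanged. No supporting data bear on why the number falls, and this single step does not separate the loss of the triple bond, the entry of the ether oxygen and the defined stereocentre.

Which of these features carries the step stays open, as does the standing of the mirror-image form of compound 3. Also open, from the compounds shown here alone, is how a methoxy group, a longer propoxy chain or a hydroxyl group on the same carbon would compare with the ethoxy branch of compound 3, and whether a tetrazole could replace the carboxylic acid.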